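Bromo in place of fluoro at the assay limit

The compounds below may be only part of what the source reports. "The series", "measured", "known", "first", "only" and "open" are said of these compounds alone.

Measured in a functional assay on COLO 205 cells (Homo sapiens) for antiproliferative activity, read by WST assay, with a stated time of 3 days; a higher number here means a weaker inhibitor, a lower number a stronger inhibitor:
- compound 1 `O=c1cc(I)n([C@@H]2O[C@H](CO)[C@@H](O)[C@H]2O)c(=O)[nH]1`: > 50000 nM
- compound 2 `O=c1[nH]c(=O)n([C@@H]2O[C@H](CO)[C@@H](O)[C@H]2O)c(I)c1F`: > 50000 nM
- compound 3 `CCc1c(F)c(=O)[nH]c(=O)n1[C@@H]1O[C@H](CO)[C@@H](O)[C@H]1O`: "not determined" (no result reported)

Compound 2 stands at > 50000 nM in this assay, which is a limit and not a number. Compound 1 likewise gives only a limit, > 50000 nM. For the measured compounds named here, the series so far rests on (the limit of > 50000 nM in this assay, at which 2 of the 3 values shown sit), and compound 3 adds no reading.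

Compound 4 `O=c1[nH]c(=O)n([C@@H]2O[C@H](CO)[C@@H](O)[C@H]2O)c(I)c1Br` comes from compound 2 through (bromo in place of fluoro on an aromatic carbon), bromo in place of fluoro on an aromatic carbon. Going by the values given here, the only measured step bearing on this change is a step that the two limits leave unreadable from compound 1 to compound 2, and it offers no size to carry over.

With compound 2 at > 50000 nM, a limit, no step beyond the scatter can be argued, and compound 4 is expected to remain at the same limit. The expected change is a number no higher from compound 2 to compound 4 (the limit leaves the size open). Compound 4 is estimated at 50000 nM, with an expected range from 15000 nM to 100000 nM.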

Compound 4, half-maximal inhibitory concentration: > 50000 nM
Compound 4 was reported as a limit (the forecaster's own chance of this, stated with the estimate: 80%); the middle value sits exactly at the limit.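

Compound 4 gives > 50000 nM in this assay, which is a limit and not a number, and its steps from compound 1 and compound 2 cannot be read. The compounds shown leave open how hydrogen, fluoro and bromo compare on that aromatic carbon, since none gives a number.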